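Methoxy on the selenium phenyl of compound 2

This account rests on a few compounds, and the source may have more. Where it says the series, first, only, none or still open, it means among the compounds named here.

Measured so far in a functional assay on SK-MEL-147 cells (Homo sapiens) for cytotoxicity, read by MTT assay, with a stated time of 24 h; on this read-out lower numbers stand for an effect already at smaller amounts and higher numbers for an effect only at larger amounts of compound
- compound 1 `CCOC(=O)c1cc([Se]Cc2ccccc2)c2cc(OC)ccc2n1` gives 40700 nM in this read-out
- compound 2 `CCOC(=O)c1cc([Se]c2ccccc2)c2cc(OC)ccc2n1` gives 33000 nM in this read-out

Compound 2 stands within the scatter of compound 1, so no order is drawn between them. Compound 3 `CCOC(=O)c1cc([Se]c2ccc(OC)cc2)c2cc(OC)ccc2n1` turns phenyl into 4-methoxyphenyl on compound 2 (methoxy in place of hydrogen on an aromatic carbon). Going by the values given here, the one measured step, a 1.2-fold lower number from compound 1 to compound 2 (0.09 log units; within the scatter) at the same group on selenium, gives only a weak guide, and no measured step adds a methoxy. No shift beyond the scatter is therefore expected. The expected size is a 1.1-fold lower number from compound 2 to compound 3 (0.04 log units; within the scatter) in this assay with no firm direction. For compound 3 the estimated value is 30000 nM with an expected range from 14000 nM to 65000 nM in this working note.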

Compound 3, half-maximal effective concentration: >= 54300 nM
Compound 3 gave a limit, no number; the forecaster's own chance of this, stated with the estimate: 10%; middle value at least 1.8-fold (0.25 log units) away from the limit.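

In this assay compound 3 gives only a limit, not a number: >= 54300 nM. Methoxy on the selenium phenyl, para to a large group, therefore brings no sign of a lower number, with an at least 1.6-fold higher number from compound 2 to compound 3 (0.21 log units; that floor lies within the scatter) and an at least 1.3-fold higher number from compound 1 to compound 3 (0.12 log units; that floor lies within the scatter), though both floors stay within the scatter. Neither step has a fixed size, only a floor: the limit of >= 54300 nM in this assay, at which 1 of the 3 values shown sits. Open, from the compounds shown here alone, is whether an amine or a carboxylic acid at this place would give a measurable number in this assay. Also open, going by these compounds, is whether a smaller group, such as fluorine, would leave the number where it stands.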